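The source may report more compounds than this note shows. Statements on the series, on what has been measured and on what is new or still open speak of the compounds shown alone.

Compound 2 `CCOC(=O)c1nn(-c2ccc(OC)cc2)/c(=N/c2nc(-c3c(C)n(C)n(-c4ccccc4)c3=O)cs2)s1` carries a methoxy on the pendant phenyl ring. For the measured compounds named here, in a functional assay on A549 cells (Homo sapiens) for cytotoxicity, read by sulforhodamine B assay, with a stated time of 72 h (a lower number here means a stronger inhibitor, a higher number a weaker inhibitor), compound 2 gives 13100 nM, the only plain number. Compound 1 `CCOC(=O)c1nn(-c2ccc(Cl)cc2)/c(=N/c2nc(-c3c(C)n(C)n(-c4ccccc4)c3=O)cs2)s1`, the chloro analogue, sits at > 100000 nM in this assay, which is a limit of the assay and not a number. The step of an at least 7.6-fold lower number from compound 1 to compound 2 (0.88 log units; beyond the scatter) is anchored on one side by that limit (the limit of > 100000 nM in this assay, at which 1 of the 2 values shown sits), so only its minimum size is known.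

Compound 3 `CCOC(=O)c1nn(-c2ccc([N+](=O)[O-])cc2)/c(=N/c2nc(-c3c(C)n(C)n(-c4ccccc4)c3=O)cs2)s1` follows from compound 2 by the change (nitro in place of methoxy on an aromatic carbon). Going by the values given here, no measured step involves a nitro group; the single step in hand, an at least 7.6-fold lower number from compound 1 to compound 2 (0.88 log units; beyond the scatter), compares chloro with methoxy and says nothing direct about nitro against methoxy. Any expectation for compound 3 in this assay therefore rests on the observation that the one para substituent change measured moved the number well beyond the scatter. The step from compound 2 to compound 3 is estimated as a 3.1-fold higher number from compound 2 to compound 3 (0.48 log units; beyond the scatter), toward a higher number. Compound 3 is expected to give 40000 nM, with a range of 10000 nM to 150000 nM, and a real chance that only a limit is reported.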

Compound 3, half-maximal inhibitory concentration: 8680 nM
Compound 3: the middle estimate sits 4.6-fold (0.66 log units) above what was measured; the measured number lies below the stated range.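

Nitro in place of methoxy at this place, para to a large group, gives a 1.5-fold lower number from compound 2 to compound 3 (0.18 log units; within the scatter) in this assay, so this assay does not separate the 4-methoxyphenyl and 4-nitrophenyl compounds. Chloro is the substituent that stands apart among the three: the step of an at least 11-fold lower number from compound 1 to compound 3 (1.06 log units; beyond the scatter) runs in the same direction as the step of an at least 7.6-fold lower number from compound 1 to compound 2 (0.88 log units; beyond the scatter), and both are beyond the scatter, so the earlier methoxy-against-chloro difference is now seen with a second group in place of methoxy. Compound 1 sits at a limit of the assay and not a number, so both steps from it give only a minimum size: the limit of > 100000 nM in this assay, at which 1 of the 3 values shown sits.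

The three compounds leave open whether the agreement between methoxy and nitro holds for other groups at this place, such as an amine, a hydroxyl or a longer alkoxy chain, and whether a fluoro or bromo compound would fall with chloro or with the other two. They also leave open how much the ethyl ester on the shared core contributes, since a carboxylic acid or an amide there would test a second place in the series.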